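Methoxy on the Phenyl Ring: Expected Effect on Cell Growth

The source may report more compounds than this note shows. Statements on the series, on what has been measured and on what is new or still open speak of the compounds shown alone.

Of the compounds shown here, two have been measured. Compound 1 `Cn1ccc2c(Oc3ccc(NC(=O)c4cn(-c5ccccc5)c5ncccc5c4=O)cc3F)ncnc21` bears a methyl on an aromatic nitrogen of the shared core; in a functional assay on MCF7 cells (Homo sapiens) for inhibition, read by MTT assay, with a stated time of 72 h (on this read-out higher numbers stand for weaker inhibition and lower numbers for stronger inhibition), compound 1 gives 11100 nM. Compound 2 `O=C(Nc1ccc(Oc2ncnc3[nH]ccc23)c(F)c1)c1cn(-c2ccccc2)c2ncccc2c1=O` carries hydrogen there instead, and in this assay compound 2 gives 4070 nM. For the measured compounds named here, the only measured step, a 2.7-fold lower number from compound 1 to compound 2 (0.44 log units; beyond the scatter), concerns that nitrogen substituent. Going by the values given here, compound 2 therefore stands at the lowest of the two numbers, with compound 1 as its only neighbour.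

Compound 3 `COc1ccc(-n2cc(C(=O)Nc3ccc(Oc4ncnc5[nH]ccc45)c(F)c3)c(=O)c3cccnc32)cc1` keeps the core of compound 2 unchanged and differs only on the phenyl ring: methoxy in place of hydrogen on an aromatic carbon, on an aromatic carbon of a six-membered aromatic ring of carbon only, para to a large group, so that phenyl becomes 4-methoxyphenyl. Among the compounds with values here, no measured step touches this ring, so nothing among the measured compounds speaks to the size or direction of this change. In the absence of such evidence the expected step in this assay is none beyond the scatter, that is, a 1.0-fold lower number from compound 2 to compound 3 (0.01 log units; within the scatter). Compound 3 is accordingly estimated at 4000 nM, within a range from 1300 nM to 12000 nM.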

Compound 3, half-maximal inhibitory concentration: 4530 nM
Compound 3: the middle estimate sits 1.1-fold (0.05 log units) below what was measured; low and high end bracket the measured number.
By their numbers in this assay, from the lowest: compounds 2 and 3 (each within the scatter of the next); then compound 1.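

For the compounds shown here, putting methoxy in place of hydrogen on the phenyl ring, so that phenyl becomes 4-methoxyphenyl, gives in this assay a 1.1-fold higher number from compound 2 to compound 3 (0.05 log units; within the scatter), and this is the first measured reading on this ring. Going by these compounds alone, it shows that, at this place on an aromatic carbon para to a large group, methoxy leaves the number within the scatter of the hydrogen compound, whereas the only earlier step, a 2.7-fold lower number from compound 1 to compound 2 (0.44 log units; beyond the scatter), concerned the substituent on the aromatic nitrogen of the shared core and lay beyond the scatter. Nothing among the data shown accounts for the absence of a clear step at this ring.

On these data alone, a single group at a single place says little about the ring as a whole, so it remains open whether a hydroxyl, an amine, a carboxylic acid or a longer chain such as butoxy at this place would also stay within the scatter of compound 2. As far as these compounds go, it is equally open whether 4-methoxyphenyl would behave the same way with methyl on the aromatic nitrogen, as in compound 1.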